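The source may hold more compounds than are shown below. What is called first, only, known or untested is meant among the compounds shown, and "the series" means these compounds.

Of the compounds shown here, three built on one shared core have been measured in a functional assay on U-87MG ATCC cells for antiproliferative activity against U-87 MG (Homo sapiens), read by MTT assay, with a stated time of 48 h, tested at 10 uM; on this read-out higher numbers stand for a weaker effect at the one concentration tested and lower numbers for a stronger effect. Compound 1 `COc1ccc(-c2nc(SCC(=O)c3sc(-c4ccccc4)nc3C)[nH]c(=O)c2C#N)cc1` gives 90.4%. Compound 2 `Cc1nc(-c2ccccc2)sc1C(=O)CSc1nc(-c2ccc(Cl)c(Cl)c2)c(C#N)c(=O)[nH]1` gives 92.5%, and compound 3 `Cc1nc(-c2ccccc2)sc1C(=O)CSc1nc(-c2cccc(Cl)c2)c(C#N)c(=O)[nH]1` gives 83.7%. Compound 1 stands second highest of these three numbers, but every gap between them is within the scatter: a number 2.1 percentage points higher from compound 1 to compound 2 (within the scatter), a number 6.7 percentage points lower from compound 1 to compound 3 (within the scatter) and a number 8.8 percentage points lower from compound 2 to compound 3 (within the scatter). All three readings therefore sit close together at the one concentration tested, and none of the three can be called stronger or weaker than another.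

Compound 4 `COc1ccc(-c2nc(SCC(=O)c3sc(-c4ccc(Cl)cc4)nc3C)[nH]c(=O)c2C#N)cc1` differs from compound 1 in one place: chloro in place of hydrogen on an aromatic carbon. Among the measured compounds shown here, no measured step touches this ring; the three measured steps all exchange groups on the other aromatic ring of the core, and each stayed within the scatter. The nearest comparison in kind is the chloro exchange from compound 2 to compound 3, which also stayed within the scatter. On that basis no step beyond the scatter is expected for compound 4 in this assay, and the expected change is a number 1.4 percentage points lower from compound 1 to compound 4 (within the scatter). The estimated value for compound 4 is 89%, with a range from 78% to 98%.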

Compound 4, a percentage reported as activity, at one concentration (the size of the read-out at that concentration, not a potency): 88.3%
The estimate for compound 4 lay 0.7 percentage points above the measured number; low and high end bracket the measured number.
By their numbers in this assay, from the lowest: compounds 3, 4, 1 and 2 (each within the scatter of the next).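

In this assay, the only exchange shown on this ring, phenyl to 4-chlorophenyl, gives a number 2.1 percentage points lower from compound 1 to compound 4 (within the scatter), so a chloro on this aromatic carbon, para to a large group, leaves a reading that cannot be told apart from the one without it. The earlier steps all lay on the other aromatic ring of the core, so the new step extends the same picture to a second place: at neither ring does any exchange shown reach beyond the scatter. The exchange of hydrogen and chloro can now also be compared at both places, and the two steps do not differ by more than such pairs of steps usually do: the same change on two cores in this assay, a number 8.8 percentage points lower (within the scatter) from compound 2 to compound 3 and a number 2.1 percentage points higher (within the scatter) from compound 4 to compound 1, 10.9 percentage points apart, within the scatter of two such steps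

The compounds shown hold only hydrogen or chloro at this place, so it remains open whether a larger or very different group there, such as an amine, a carboxylic acid or a longer chain, would move the number beyond the scatter. A reading at one concentration is also not a potency, so any difference among these compounds at other concentrations remains unknown.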